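The source may hold more compounds than are shown below. What is called first, only, known or untested is meant among the compounds shown, and "the series" means these compounds.

In a functional assay on SK-OV-3 cells (Homo sapiens) for inhibition, read by CCK-8 assay, with a stated time of 70 h (a lower number here means a stronger inhibitor, a higher number a weaker inhibitor), three compounds built on a shared core have been measured. Compound 1 `COC(=O)c1ccc(COc2ccc(OCCOCCNC3CCCC3)cc2)cc1` gives 6990 nM. Compound 2 `Nc1cccc(COc2ccc(OCCOCCNC3CCCC3)cc2)c1` gives 10800 nM, and a 1.5-fold higher number from compound 1 to compound 2 (0.19 log units; within the scatter) leaves the two within the scatter of each other. Compound 3 `COC(=O)c1ccccc1COc1ccc(OCCOCCNC2CCCC2)cc1` stands at > 100000 nM, which is a limit of the assay and not a number.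

Compound 4 `O=[N+]([O-])c1ccccc1COc1ccc(OCCOCCNC2CCCC2)cc1` has nitro in place of methoxycarbonyl on an aromatic carbon, ortho to a large group: nitro in place of methoxycarbonyl on an aromatic carbon. For the measured compounds named here, no measured step makes this exchange. The nearest evidence is the change to the 2-(methoxycarbonyl)phenyl group, with an at least 14-fold higher number from compound 1 to compound 3 (1.15 log units; beyond the scatter) and an at least 9.2-fold higher number from compound 2 to compound 3 (0.96 log units; beyond the scatter), both beyond the scatter. Compound 4 keeps a group at that same place, so it is expected to stay weak, and only a modest move toward a lower number is anticipated, if any. The estimated step is an at least 2.5-fold lower number from compound 3 to compound 4 (0.39 log units; beyond the scatter). For compound 4, the expected value is 40000 nM, with an estimated range of 12000 nM to 100000 nM.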

Compound 4, half-maximal inhibitory concentration: 5370 nM
For compound 4 the middle estimate is 7.4-fold (0.87 log units) above the measured one, and the stated range ends above it.
By their numbers in this assay, from the lowest: compounds 4, 1 and 2 (each within the scatter of the next). At a limit, above all of these: compound 3.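

In this assay, this place does not by itself carry the loss seen in compound 3: exchanging methoxycarbonyl for nitro on an aromatic carbon, ortho to a large group, gives an at least 18-fold lower number from compound 3 to compound 4 (1.27 log units; beyond the scatter), so the loss goes with the 2-(methoxycarbonyl)phenyl group, not with the place alone. Compound 4 also sits level with the other two measured compounds, since a 2.0-fold lower number from compound 2 to compound 4 (0.30 log units; within the scatter) and a 1.3-fold lower number from compound 1 to compound 4 (0.11 log units; within the scatter) allow no order among them. Going by these compounds, compound 3 stands at a limit and not at a number, so the full size of the first step stays unknown: the limit of > 100000 nM in this assay, at which 1 of the 4 values shown sits.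

The compounds shown leave open whether an amine, a nitrile or a carboxylic acid at this same place would stand with nitro or with methoxycarbonyl. What separates these two groups here cannot be told from this single pair.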